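This account rests on a few compounds, and the source may have more. Where it says the series, first, only, none or still open, it means among the compounds named here.

Measured so far:
compound 1 `Oc1cccc(-c2cc(-c3cccs3)cc(-c3ccccc3O)n2)c1` with 83.2%
compound 2 `Oc1cccc(-c2cc(-c3cccs3)cc(-c3cccc(O)c3)n2)c1` with 91.7%
compound 3 `Oc1ccccc1-c1cc(-c2ccsc2)cc(-c2ccccc2O)n1` with 0%

All three were tested in an assay on isolated protein for inhibition of DNA topoisomerase 1 (Homo sapiens), with a stated time of 30 min, tested at 100 uM; on this read-out higher numbers stand for a stronger effect at the one concentration tested and lower numbers for a weaker effect. Compound 1 and compound 2 share a core and differ in one place: 3-hydroxyphenyl in place of 2-hydroxyphenyl on an aromatic carbon. That change gave a number 8.5 percentage points higher from compound 1 to compound 2 (within the scatter), so the two hydroxyphenyl positions look equivalent here. Compound 3 stands apart: in this assay compound 3 gives 0%, far beneath both others. How the core of compound 3 differs from the core of compound 1 is not broken down here.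

Compound 4 `Oc1cccc(-c2cc(-c3ccsc3)cc(-c3ccccc3O)n2)c1` has not yet been measured. It arises from compound 3 by 3-hydroxyphenyl in place of 2-hydroxyphenyl on an aromatic carbon. This is the same kind of change as from compound 1 to compound 2, though the surroundings differ: in compound 3 the place is meta to a 2-hydroxyphenyl group and meta to a thiophen-3-yl group, where in compound 1 it is meta to a 3-hydroxyphenyl group and meta to a thiophen-2-yl group. Because a number 8.5 percentage points higher from compound 1 to compound 2 (within the scatter) lay within the scatter, only a small step is expected from compound 3, and compound 3 already gives the lowest of the three numbers with 0%. The step expected is a number 10 percentage points higher from compound 3 to compound 4 (within the scatter). Compound 4 is therefore estimated at 10%, most likely between 0% and 40%.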

Compound 4, a percentage reported as inhibition, at one concentration (the size of the read-out at that concentration, not a potency): 10.2%
Beside the measured number, compound 4's estimate is 0.2 percentage points below it; measured number inside the range.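

In this assay, 3-hydroxyphenyl in place of 2-hydroxyphenyl gave a number 10.2 percentage points higher from compound 3 to compound 4 (beyond the scatter), and the size of this step matches that of the same change on the other core: the same change on two cores in this assay, a number 8.5 percentage points higher (within the scatter) from compound 1 to compound 2 and a number 10.2 percentage points higher (beyond the scatter) from compound 3 to compound 4, 1.7 percentage points apart, within the scatter of two such steps. The change therefore carries over in size between these two cores, but it does not bring the number back, and the larger effect belongs to the thiophene: thiophen-3-yl in place of thiophen-2-yl gave a number 73 percentage points lower from compound 1 to compound 4 (beyond the scatter). Two cores are a small sample, so this does not show that the step would hold on a third core, and it does not explain why the thiophene swap weighs so much more.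

The compounds shown leave open how an aminophenyl or a methoxyphenyl group would behave in place of the hydroxyphenyl groups. Also open, as far as these compounds go, is whether a furan ring or a plain phenyl ring could stand in place of the thiophen-2-yl group.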